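This account rests on a few compounds, and the source may have more. Where it says the series, first, only, none or still open, it means among the compounds named here.

Compound 1 `CCOc1ccc(C(=O)/C=C/c2c(/C=C/c3ccc(OC)cc3)cc(OC)cc2OC)cc1` carries a 4-ethoxyphenyl group on the shared core; in a functional assay on B16-F10 cells (Mus musculus) for antiproliferative activity, read by MTT assay, with a stated time of 48 h (on this read-out higher numbers stand for weaker inhibition and lower numbers for stronger inhibition), compound 1 gives 6.4 ug/mL. Compound 2 `COc1ccc(/C=C/c2cc(OC)cc(OC)c2/C=C/C(=O)c2ccccc2)cc1` gives 3.7 ug/mL and compound 3 `COc1ccc(/C=C/c2cc(OC)cc(OC)c2/C=C/C(=O)c2ccc(N)cc2)cc1` gives 2.8 ug/mL. Compound 1 stands apart from compound 3 by a 2.3-fold lower number from compound 1 to compound 3 (0.36 log units; beyond the scatter), while a 1.7-fold lower number from compound 1 to compound 2 (0.24 log units; within the scatter) and a 1.3-fold lower number from compound 2 to compound 3 (0.12 log units; within the scatter) stay within the scatter. Compound 4 `CCCC(C)Oc1ccc(C(=O)/C=C/c2c(/C=C/c3ccc(OC)cc3)cc(OC)cc2OC)cc1` differs from compound 1 by propyl in place of hydrogen on a saturated chain carbon bound to an oxygen on an aromatic ring and a saturated chain carbon. Going by the values given here, the measured steps replace the ethoxy group rather than extend it, so none speaks directly to the new propyl; they show only that change at this position gives at most a modest shift, as in a 2.3-fold lower number from compound 1 to compound 3 (0.36 log units; beyond the scatter). No step beyond the scatter is therefore expected in this assay. Compound 4 is estimated at 6 ug/mL, between 3 ug/mL and 12 ug/mL. The expected step is a 1.1-fold lower number from compound 1 to compound 4 (0.03 log units; within the scatter).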

Compound 4, half-maximal inhibitory concentration: 6.7 ug/mL
Compound 4: middle estimate off by 1.1-fold (0.05 log units), on the low side; low and high end bracket the measured number.
By their numbers in this assay, from the lowest: compounds 3, 2, 1 and 4 (each within the scatter of the next, the first and the last beyond it).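

In this assay, growing the ethoxy into 1-methylbutoxy gives the first direct read on the chain itself: a 1.0-fold higher number from compound 1 to compound 4 (0.02 log units; within the scatter) shows that propyl on this saturated chain carbon brings no shift beyond the scatter. Set against the other groups at this place, 1-methylbutoxy gives a 1.8-fold higher number from compound 2 to compound 4 (0.26 log units; within the scatter) against hydrogen and a 2.4-fold higher number from compound 3 to compound 4 (0.38 log units; beyond the scatter) against amino, and only the step against amino clears the scatter. Open, as far as these compounds go, is whether a straight hexyloxy chain, a benzyloxy group or a chain ending in a carboxylic acid would hold the number as well. No measurement shown here accounts for any of these steps.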